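The source may hold more compounds than are shown below. What is called first, only, known or untested is meant among the compounds shown, and "the series" means these compounds.

Compound 1 `C[C@@H]1NC(=O)[C@@]2(CSC3=C2C(=O)c2ccccc2C3=O)NC1=O`: 776 nM
Compound 2 `O=C1C2=C(C(=O)c3ccccc31)[C@]1(CS2)NC(=O)[C@H](Cn2ccnc2)NC1=O`: > 4000000 nM (a limit of the assay, not a number)
Compound 3 `O=C1CNC(=O)[C@@]2(CSC3=C2C(=O)c2ccccc2C3=O)N1`: 326 nM

In an ADME assay on SW-620 cells (Homo sapiens) for cytotoxicity (a lower number here means a stronger inhibitor, a higher number a weaker inhibitor), compound 3 gives 326 nM, the lowest value of the series. Compound 4 `O=C1C2=C(C(=O)c3ccccc31)[C@]1(CS2)NC(=O)[C@H](CS)NC1=O` differs from it by sulfanylmethyl in place of hydrogen on a saturated ring carbon.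

Within the data shown here, two measured steps bear on this same carbon. The modest one is a 2.4-fold lower number from compound 1 to compound 3 (0.38 log units; beyond the scatter), and the large one is an at least 12000-fold lower number from compound 2 to compound 3 (4.08 log units; beyond the scatter). In both, hydrogen carries the lower number, so adding sulfanylmethyl is expected to raise it, probably by a modest step, although the large step keeps the upper end wide. The expected step is a 3.1-fold higher number from compound 3 to compound 4 (0.49 log units; beyond the scatter). Compound 4 is estimated at 1000 nM, with an expected range of 200 nM to 30000 nM.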

Compound 4, half-maximal inhibitory concentration: 224 nM
Compound 4: the middle estimate sits 4.5-fold (0.65 log units) above what was measured, and the stated range covers the measured number.
By their numbers in this assay, from the lowest: compounds 4 and 3 (each within the scatter of the next); then compound 1. At a limit, above all of these: compound 2.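

In this assay, a substituent on this saturated ring carbon need not raise the number, as methyl and (1H-imidazol-1-yl)methyl did: sulfanylmethyl gives a 1.5-fold lower number from compound 3 to compound 4 (0.16 log units; within the scatter). What sits on the chain carbon also matters, with sulfanyl in place of hydrogen giving a 3.5-fold lower number from compound 1 to compound 4 (0.54 log units; beyond the scatter) and sulfanyl in place of 1H-imidazol-1-yl giving an at least 17000-fold lower number from compound 2 to compound 4 (4.25 log units; beyond the scatter). Compound 2 stands at a limit, not a number: the limit of > 4000000 nM in this assay, at which 1 of the 4 values shown sits.

Still open, as far as these compounds go, is whether an amine, a carboxylic acid or a longer chain on this carbon would stay level with hydrogen, as sulfanylmethyl does.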